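Removing a Chloro Group from a Hydrazone Antiproliferative

The compounds below may be only part of what the source reports. "The series", "measured", "known", "first", "only" and "open" are said of these compounds alone.

Compound 1, `COc1ccc(OC)c(/C=C/c2nnc(Nc3ccc(Cl)cc3)o2)c1`: 26800 nM
Compound 2, `COc1ccc(OC)c(/C=C/C(=O)N/N=C/c2ccc(Cl)cc2)c1`: 372 nM

In a functional assay on SK-MEL-28 cells (Homo sapiens) for antiproliferative activity, read by sulforhodamine B assay, with a stated time of 48 h (a higher number here means a weaker inhibitor of growth, a lower number a stronger inhibitor of growth), compound 2 gives the lower of the two numbers, and compound 1 stands far above it, beyond the scatter. Compound 3, `COc1ccc(OC)c(/C=C/C(=O)N/N=C/c2ccccc2)c1`, differs from compound 2 by hydrogen in place of chloro on an aromatic carbon. Among the measured compounds shown here, no two measured compounds differ in just one place, so the size of this kind of step is not known from the data; a modest weakening, near the edge of the scatter, seems the most likely outcome. Compound 3 is expected to give about 650 nM, between 150 nM and 2800 nM, with an expected step of a 1.7-fold higher number from compound 2 to compound 3 (0.24 log units; within the scatter).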

Compound 3, concentration for 50% growth inhibition: 8890 nM
Estimate against measurement, compound 3: 14-fold (1.14 log units) below; measured number above the stated range.
By their numbers in this assay, from the lowest: compound 2; then compound 3; then compound 1.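

Replacing the chloro group with hydrogen gives a 24-fold higher number from compound 2 to compound 3 (1.38 log units; beyond the scatter) in this assay and shows that this position on the aromatic ring is far from neutral for this pair. Losing one heavy atom separates the stronger inhibitor of growth, compound 2, from the much weaker compound 3. Nothing available explains the size of this step.

Going by these compounds, it remains open whether a fluoro, bromo, methyl or methoxy group at the same place would match chloro or fall closer to hydrogen.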